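The source may report more compounds than this note shows. Statements on the series, on what has been measured and on what is new or still open speak of the compounds shown alone.

Compound 1, `O=S(=O)(Nc1ccc(-c2nc3ccccc3o2)cc1)c1cccc(F)c1`: > 63000 nM
Compound 2, `O=S(=O)(Nc1ccc(-c2nc3ccccc3o2)cc1)c1ccc(Cl)c(C(F)(F)F)c1`: > 63000 nM
Compound 3, `C=Cc1ccc(S(=O)(=O)Nc2ccc3oc(-c4ccccc4)nc3c2)cc1`: > 63000 nM

Each of these three figures is a limit of the assay rather than a measured number. In an assay on isolated protein for inhibition of malate dehydrogenase, mitochondrial (Sus scrofa), with stated times of 45 min and 30 min (on this read-out higher numbers stand for weaker inhibition and lower numbers for stronger inhibition), compound 1 gives only a limit, and it is the same limit that the other two compounds show: the limit of > 63000 nM in this assay, at which 3 of the 3 values shown sit. No ordering among the three can therefore be drawn from this assay, and compound 1 stands nowhere in particular among them beyond sharing that limit.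

Compound 4, `O=S(=O)(Nc1ccc(-c2nc3ccccc3o2)cc1)c1ccccc1O`, has not been measured in this assay. It differs from compound 1 by 2-hydroxyphenyl in place of 3-fluorophenyl on a sulfonyl sulfur. Going by the values given here, no step between two measured compounds is available to guide the expectation, since every value shown is a limit. The three compounds carry different groups on the sulfonyl sulfur and all sit at the limit, so compound 4 is expected to behave no differently, with a step from compound 1 of a step that the limit leaves unreadable from compound 1 to compound 4 meaning no change beyond the scatter. Compound 4 is estimated at 80000 nM, within a range from 20000 nM to 300000 nM, most likely again reported as a limit.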

Compound 4, half-maximal inhibitory concentration: > 63000 nM
Compound 4: a limit, no number; the forecaster's own chance of this, stated with the estimate: 80%; the middle value does not contradict the limit.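

Compound 1 and compound 4 each give only a limit in this assay, so no step between them can be read: the limit of > 63000 nM in this assay, at which 4 of the 4 values shown sit.

The compounds shown leave open how strongly any of them inhibits the enzyme, and whether any group on the sulfonyl sulfur would give a measurable value.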